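Positional Swap of a Chlorophenyl Group on a Shared Core

This account rests on a few compounds, and the source may have more. Where it says the series, first, only, none or still open, it means among the compounds named here.

Four compounds built on one shared core are considered. In a functional assay on HCT-15 cells (Homo sapiens) for cytotoxicity, read by CCK-8 assay and cell counting, with a stated time of 2 days (a lower number here means a stronger inhibitor, a higher number a weaker inhibitor), compound 1 `Oc1cccc(-c2cc(-c3cccnc3)nc(-c3cccc(Cl)c3)c2)c1` has the entry "not determined" (no result reported), and compound 2 `Oc1cccc(-c2cc(-c3cccc(Cl)c3)nc(-c3ccccn3)c2)c1` has the entry "not determined" (no result reported); for both, no number is available. Compound 3 `Oc1cccc(-c2cc(-c3ccc(Cl)cc3)nc(-c3ccsc3)c2)c1` is therefore the only compound with a measurement: in this assay compound 3 gives 8850 nM, and on the numbers shown it stands alone, neither stronger nor weaker than any comparison, since none exists.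

Compound 4 `Oc1cccc(-c2cc(-c3ccsc3)nc(-c3cccc(Cl)c3)c2)c1` differs from compound 3 in a single place: 3-chlorophenyl in place of 4-chlorophenyl on an aromatic carbon. Among the measured compounds shown here, no step between two measured compounds is available that would show how such a rearrangement of the same atoms moves the readout, so there is no foundation for expecting a shift in either direction. The expectation is accordingly that the step from compound 3 to compound 4 in this assay, a 1.1-fold lower number from compound 3 to compound 4 (0.04 log units; within the scatter), stays within the usual scatter. The estimated value for compound 4 in this assay is 8000 nM, with an expected range from 3000 nM to 25000 nM.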

Compound 4, half-maximal inhibitory concentration: 2510 nM
Estimate against measurement, compound 4: 3.2-fold (0.50 log units) above; measured number below the stated range.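

In this assay, exchanging 4-chlorophenyl for 3-chlorophenyl on the aromatic carbon next to the ring nitrogen gives a 3.5-fold lower number from compound 3 to compound 4 (0.55 log units; beyond the scatter). Among the compounds shown here, this is the first readable step on the shared core, and it shows that this place responds to a rearrangement of the same atoms: both groups have the same heavy-atom count, yet the number moves beyond the usual scatter, though only modestly. Nothing available bears on why the number moves.

From the compounds shown here alone, it remains open how a plain phenyl group, or a phenyl group carrying an amine or a carboxylic acid, would read at this place. Going by these compounds, it is also open whether the same step would appear if a pyridine ring stood in place of the thiophen-3-yl group.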